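This account rests on a few compounds, and the source may have more. Where it says the series, first, only, none or still open, it means among the compounds named here.

In a functional assay on DU-145 cells (Homo sapiens) for inhibition, read by trypan blue exclusion, with a stated time of 96 h (on this read-out higher numbers stand for weaker inhibition of growth and lower numbers for stronger inhibition of growth), compound 1 `Cc1ccc(S/C(=C/c2ccc(Br)cc2)C(=O)c2ccc(Cl)cc2)cc1` gives 25000 nM and compound 2 `Cc1ccc(S/C(=C/c2sccc2C)C(=O)c2ccc(Br)cc2)cc1` gives 50000 nM, so these two numbers lie within the usual scatter of each other. Compound 3 `Cc1ccc(S/C(=C/c2cc(Cl)cc(Cl)c2Cl)C(=O)c2ccc(Cl)cc2)cc1` differs from compound 1 by 2,3,5-trichlorophenyl in place of 4-bromophenyl on a double-bonded chain carbon bound to a double-bonded chain carbon: 2,3,5-trichlorophenyl stands in place of 4-bromophenyl on a double-bonded chain carbon bound to a double-bonded chain carbon. Within the data shown here, no two measured compounds differ in one place only, so the data give no direct guide to this change. The expected step of a 1.3-fold lower number from compound 1 to compound 3 (0.10 log units; within the scatter) in this assay is none beyond the scatter. For compound 3 the estimated value is 20000 nM, with an expected range of 6000 nM to 60000 nM.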

Compound 3, concentration for 50% growth inhibition: 50000 nM
The estimate for compound 3 lay 2.5-fold (0.40 log units) below the measured number; the measured number falls inside the stated range.
By their numbers in this assay, from the lowest: compounds 1, 2 and 3 (each within the scatter of the next).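

Among these compounds, the first direct comparison at this position comes from placing 2,3,5-trichlorophenyl in place of 4-bromophenyl on a double-bonded chain carbon bound to a double-bonded chain carbon. In this assay this gives a 2.0-fold higher number from compound 1 to compound 3 (0.30 log units; within the scatter). The ring at this place can therefore carry three chlorines instead of one bromine with no difference beyond the scatter, and no supporting evidence bears on this result.

As far as these compounds go, it remains open whether a different kind of group on this ring, such as an amine or a carboxylic acid, would give a step beyond the scatter.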